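This account rests on a few compounds, and the source may have more. Where it says the series, first, only, none or still open, it means among the compounds named here.

Compound 3, `CC(C)c1c(C(=O)N(C)Cc2ccccc2)nn(-c2ccc(F)cc2)c1OC[C@@H](O)C[C@@H](O)CC(=O)O`, sits second highest of the three numbers in an assay on microsomes from liver for inhibition of 3-hydroxy-3-methylglutaryl-coenzyme A reductase (Rattus norvegicus) (a higher number here means a weaker inhibitor, a lower number a stronger inhibitor), where compound 3 gives 5.2 nM. Its nearest neighbour is compound 1, `CC(C)c1c(C(=O)N(C)Cc2ccccc2)nn(-c2ccc(F)cc2)c1CC[C@@H](O)C[C@@H](O)CC(=O)O`, which in this assay gives 6.2 nM; the change a 1.2-fold lower number from compound 1 to compound 3 (0.08 log units; within the scatter) lies within the scatter. Furthest away is compound 2, `CC(C)c1c(C(=O)N2CCC[C@H](c3ccccc3)C2)nn(-c2ccc(F)cc2)c1CC[C@@H](O)C[C@@H](O)CC(=O)O`, which in this assay gives 2.1 nM.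

Compound 4, `Cc1ccc(CNC(=O)c2nn(-c3ccc(F)cc3)c(OC[C@@H](O)C[C@@H](O)CC(=O)O)c2C(C)C)cc1`, differs from compound 3 in one place: (4-methylbenzyl)amino in place of benzyl(methyl)amino on a carbonyl carbon. The amide nitrogen is thus changed from a tertiary to a secondary one while the atom count is kept.

Of the measured steps only one touches the amide: a 3.0-fold lower number from compound 1 to compound 2 (0.47 log units; beyond the scatter), a modest improvement on replacing the same benzyl(methyl)amino group by a ring-fused variant. For the measured compounds named here, the change to compound 4 is a different one, so that step gives only a loose guide, and no step within the data alters an amide substituent in this way. Compound 4 is therefore expected to stay close to compound 3, with a 1.0-fold lower number from compound 3 to compound 4 (0.02 log units; within the scatter) the estimated step, and an estimated value for compound 4 of 5 nM in this assay, within a range from 2 nM to 13 nM.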

Compound 4, half-maximal inhibitory concentration: 15 nM
Compound 4: the middle estimate sits 3.0-fold (0.48 log units) below what was measured, outside the stated range (above it).
By their numbers in this assay, from the lowest: compound 2; then compounds 3 and 1 (each within the scatter of the next); then compound 4.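

On a carbonyl carbon, a swap that keeps the same atoms, joined differently, and brings in the amide hydrogen still moves the number, with this assay recording a 2.9-fold higher number from compound 3 to compound 4 (0.46 log units; beyond the scatter) for this change. For the compounds shown here, the only earlier step at this place ran the other way with a 3.0-fold lower number from compound 1 to compound 2 (0.47 log units; beyond the scatter) on the 6-carboxy-3,5-dihydroxyhexyl chain, so the substituent on this carbonyl can shift the number in either direction. Nothing in the data shown accounts for the rise.

The (4-methylbenzyl)amino group differs in two ways at once, losing the methyl on the nitrogen and gaining one on the ring, so the compounds shown cannot divide the step between the two. Plain benzylamino or (4-methylbenzyl)(methyl)amino on the same carbonyl carbon would separate them, and whether the swap behaves alike with the 6-carboxy-3,5-dihydroxyhexyl chain also stays open.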